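This account rests on a few compounds, and the source may have more. Where it says the series, first, only, none or still open, it means among the compounds named here.

Measured so far:
compound 1, `CC(=O)c1ccc(-c2ccc(OCc3cc(C(=O)NS(=O)(=O)c4ccccc4)oc3C)cc2)cc1`: 20 nM
compound 2, `Cc1oc(C(=O)O)cc1Nc1ccc(-c2ccccc2)cc1`: 1400 nM
compound 3, `CC(C)c1oc(C(=O)O)cc1COc1ccc(-c2ccccc2)cc1`: 3000 nM

Among these three, compound 3 has the highest number in an assay on cells for displacement of a labelled ligand from prostaglandin E2 receptor EP4 subtype (Homo sapiens), read by scintillation counting (on this read-out higher numbers stand for weaker inhibition and lower numbers for stronger inhibition), meaning the weakest inhibition shown; compound 2 sits nearest to it, and compound 1 lies far away with a much lower number. Compound 4, `O=C(O)c1cc(COc2ccc(-c3ccccc3)cc2)co1`, has not yet been measured in this assay. It differs from compound 3 in one place: hydrogen in place of isopropyl on an aromatic carbon. Among the measured compounds shown here, with no measured pair showing this exact change, the expected step can only be guessed from the gap between compound 3 and the others. The expectation is a small rise in the number, possibly within the usual scatter, so compound 4 is estimated at 4000 nM (range 1500 nM to 12000 nM), a step of a 1.3-fold higher number from compound 3 to compound 4 (0.12 log units; within the scatter).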

Compound 4, inhibition constant: 2000 nM
For compound 4 the middle estimate is 2.0-fold (0.30 log units) above the measured one; the measured number falls inside the stated range.
By their numbers in this assay, from the lowest: compound 1; then compounds 2, 4 and 3 (each within the scatter of the next, the first and the last beyond it).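

Putting hydrogen in place of isopropyl on this aromatic carbon, next to the ring oxygen, gives a 1.5-fold lower number from compound 3 to compound 4 (0.18 log units; within the scatter) in this assay. On this read-out, isopropyl and hydrogen at this position cannot be told apart, so these two compounds show no need for the 3 heavy atoms of isopropyl here. Nothing available accounts for this result.

As far as these compounds go, what an amine, a fluorine atom or a phenyl ring on this carbon would do remains open. So does whether the same change would read alike on the core of compound 1.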